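Ester and sulfonamide side chains at the cytotoxicity ceiling

A few compounds are considered here, and "the series" means these few. Any claim that something is new, unique, unknown or untested is made for them only; others in the source may bear on it.

Measured in an ADME assay on Vero cells (Chlorocebus sabaeus) for cytotoxicity, read by MTT assay, with a stated time of 48 h; on this read-out lower numbers stand for stronger inhibition and higher numbers for weaker inhibition:
Compound 1 `O=C(OC1CCC(CN2CCN(c3cc(=O)c4cc(C(F)(F)F)cc([N+](=O)[O-])c4s3)CC2)CC1)c1ccccc1` gives > 64 ug/mL, a limit of the assay and not a number.
Compound 2 `O=c1cc(N2CCN(CC3CCC(NS(=O)(=O)c4ccccc4)CC3)CC2)sc2c([N+](=O)[O-])cc(C(F)(F)F)cc12` gives > 64 ug/mL, a limit of the assay and not a number.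
Compound 3 `O=C(OC1CCC(CN2CCN(c3cc(=O)c4cc(C(F)(F)F)cc([N+](=O)[O-])c4s3)CC2)CC1)c1cccc(F)c1` gives > 64 ug/mL, a limit of the assay and not a number.

In this assay compound 2 therefore stands only at a limit, and the two further values shown are limits as well, so nothing among the three can be ordered; all sit together at the limit of > 64 ug/mL in this assay, at which 3 of the 3 values shown sit.

The step under study goes from compound 2 to compound 4 `COc1cccc(C(=O)OC2CCC(CN3CCN(c4cc(=O)c5cc(C(F)(F)F)cc([N+](=O)[O-])c5s4)CC3)CC2)c1`. The change is ((3-methoxyphenyl)carbonyl)oxy in place of (phenylsulfonyl)amino on a saturated ring carbon.

Among the compounds with values here, two measured steps bear on the same position of the saturated ring: a step that the two limits leave unreadable from compound 1 to compound 2 and a step that the two limits leave unreadable from compound 2 to compound 3. Neither has a readable size, because both ends rest at the limit of > 64 ug/mL in this assay, at which 3 of the 3 values shown sit. The remaining step, a step that the two limits leave unreadable from compound 1 to compound 3, is equally unreadable. Nothing in the numbers therefore points to a shift in either direction beyond the scatter when the ester returns in place of the sulfonamide, and the expected step is a step that the limit leaves unreadable from compound 2 to compound 4.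

Compound 4 is accordingly expected to give 90 ug/mL in this assay, within a range of 40 ug/mL to 250 ug/mL, most likely reported again only as a limit.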

Compound 4, half-maximal inhibitory concentration: > 64 ug/mL
Compound 4 was reported as a limit; the forecaster's own chance of this, stated with the estimate: 85%; the middle value lies beyond the limit too.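

In this assay compound 4 gives > 64 ug/mL, a limit of the assay and not a number. Its steps to compound 1, compound 2 and compound 3 cannot be read, because all four compounds rest at the same limit: the limit of > 64 ug/mL in this assay, at which 4 of the 4 values shown sit.

The compounds shown leave open how the ester and sulfonamide side chains would rank in this assay, since none has a numerical value.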